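The source may hold more compounds than are shown below. What is called first, only, known or untested is meant among the compounds shown, and "the series" means these compounds.

In a functional assay on SW-620 cells (Homo sapiens) for antiproliferative activity, read by MTT assay, with a stated time of 72 h, in the presence of a further agent that is not named here (on this read-out higher numbers stand for weaker inhibition and lower numbers for stronger inhibition), the measured compounds stand as follows:

Compound 1 `Nc1nc2[nH]c(CCSCCC(=O)NCc3ccccn3)cc2c(=O)[nH]1`: 11900 nM
Compound 2 `Nc1nc2[nH]c(CCSCCC(=O)NCc3ccncc3)cc2c(=O)[nH]1`: 24800 nM
Compound 3 `Nc1nc2[nH]c(CCSCC(=O)NCc3ccccn3)cc2c(=O)[nH]1`: 36100 nM

Compound 2 differs from compound 1 by pyridin-4-yl in place of pyridin-2-yl on a saturated chain carbon bound to an amide-type nitrogen, and this change gave a 2.1-fold higher number from compound 1 to compound 2 (0.32 log units; beyond the scatter). Compound 3 carries the same pyridin-2-yl group as compound 1 on a shorter chain; the difference between the two cores is not broken down here. Compound 4 `Nc1nc2[nH]c(CCSCC(=O)NCc3ccncc3)cc2c(=O)[nH]1` has not yet been measured. It differs from compound 3 by pyridin-4-yl in place of pyridin-2-yl on a saturated chain carbon bound to an amide-type nitrogen, the same change as that from compound 1 to compound 2, made on the core of compound 3. For the measured compounds named here, on the strength of the step seen for compound 2, the step of a 2.1-fold higher number from compound 3 to compound 4 (0.32 log units; beyond the scatter) is expected, resting on the one step in which this change has been seen because that step is a 2.1-fold higher number from compound 1 to compound 2 (0.32 log units; beyond the scatter). The value of compound 4 is accordingly estimated at 75000 nM, expected to fall between 30000 nM and 180000 nM.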

Compound 4, half-maximal inhibitory concentration: 22700 nM
For compound 4 the middle estimate is 3.3-fold (0.52 log units) above the measured one; the measured number lies below the stated range.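

In this assay, pyridin-4-yl in place of pyridin-2-yl on the core of compound 3 gave a 1.6-fold lower number from compound 3 to compound 4 (0.20 log units; within the scatter), so on this core the change separates the two compounds no more than repeated measurements would. The change therefore did not carry over from the core of compound 1 as a fixed step: the same change on two cores in this assay, a 2.1-fold higher number (0.32 log units; beyond the scatter) from compound 1 to compound 2 and a 1.6-fold lower number (0.20 log units; within the scatter) from compound 3 to compound 4, 3.3-fold (0.52 log units) apart, beyond the scatter of two such steps. These two pairs do not show why the cores differ, nor how the change would behave on any further core.

The compounds shown leave open how a phenyl ring in place of the pyridine, or a longer chain, would read on these cores. On these data alone, whether the change behaves the same way in other cell lines also stays open.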